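A few compounds are considered here, and "the series" means these few. Any claim that something is new, unique, unknown or untested is made for them only; others in the source may bear on it.

In a functional assay on MDA-MB-435S cells (Homo sapiens) for cytotoxicity, read by MTT assay (a lower number here means a stronger inhibitor, a higher number a weaker inhibitor), compound 1 `COc1ccc(-c2oc3c(CC=C(C)C)c(OCCO)cc(O)c3c(=O)c2OCCO)cc1` reaches only a limit of the assay, > 100000 nM. Compound 2 `CCOC(=O)C(C)Oc1cc(O)c2c(=O)c(O)c(-c3ccc(OC)cc3)oc2c1CC=C(C)C` gives 2500 nM, the lowest of the two numbers in the series, and compound 3 `COc1ccc(-c2oc3c(CC=C(C)C)c(OCCCO)cc(O)c3c(=O)c2OCCCO)cc1` gives 21800 nM, the gap between the two lying beyond the scatter. Compound 4 `COc1ccc(-c2oc3c(CC=C(C)C)c(OCC(=O)O)cc(O)c3c(=O)c2O)cc1` has not yet been measured in this assay. Against compound 2 it carries carboxymethyl in place of 1-(ethoxycarbonyl)ethyl on an oxygen on an aromatic ring. Among the measured compounds shown here, no measured pair shows this exchange, so the step can only be estimated from the surrounding numbers. The step from compound 2 to compound 4 is expected to be a weakening, a 4.8-fold higher number from compound 2 to compound 4 (0.68 log units; beyond the scatter), of a size beyond the scatter. Compound 4 is estimated at 12000 nM, with a range from 3000 nM to 50000 nM.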

Compound 4, half-maximal inhibitory concentration: 13500 nM
The estimate for compound 4 lay 1.1-fold (0.05 log units) below the measured number, and the stated range covers the measured number.
By their numbers in this assay, from the lowest: compound 2; then compounds 4 and 3 (each within the scatter of the next). At a limit, above all of these: compound 1.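

The exchange of 1-(ethoxycarbonyl)ethyl for carboxymethyl on an oxygen on an aromatic ring gives the series its first single-place comparison, and in this assay it is a modest weakening, a 5.4-fold higher number from compound 2 to compound 4 (0.73 log units; beyond the scatter). The group on this oxygen alone therefore moves the number beyond the scatter, yet compound 4 still gives a measured value rather than a limit. Nothing shown gives a cause for this step. Going by these compounds, the exchange alters the ester and the chain together, so their separate shares remain open. An ethoxycarbonylmethyl or 1-carboxyethyl group on the same oxygen would separate them, and an amide there is a further open case.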